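The source may report more compounds than this note shows. Statements on the series, on what has been measured and on what is new or still open speak of the compounds shown alone.

In an ADME assay on BHK-21 cells (Mesocricetus auratus) for cytotoxicity, read by MTT assay, with a stated time of 48 h (on this read-out higher numbers stand for lower toxicity in this test and lower numbers for higher toxicity in this test), compound 1, the bromophenyl analogue `CC1(C)CC(=O)C2=C(C1)N(c1ccccc1)C(c1cccc(Br)c1)N(c1ccccc1)C2`, reaches only the limit of the assay, > 20000 nM, and no number is given for it. Among the measured compounds shown here, compound 2, `CC1(C)CC(=O)C2=C(C1)N(c1ccccc1)C(c1ccc(Br)cc1)N(c1ccc(F)cc1)C2`, is the one compound of the pair with a number in this assay, where compound 2 gives 10000 nM. Its place can only be set against (the limit of > 20000 nM in this assay, at which 1 of the 2 values shown sits), since the other value is a limit rather than a measurement.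

Compound 3, `CC1(C)CC(=O)C2=C(C1)N(c1ccccc1)C(c1ccc(Br)cc1)N(c1ccc(Oc3ccccc3)cc1)C2`, arises from compound 2 by the change (phenoxy in place of fluoro on an aromatic carbon), a phenoxy in place of fluoro on an aromatic carbon. For the measured compounds named here, no step between measured compounds is available to guide the size of the change. Compound 3 is therefore expected to stay close to compound 2, with a step of a 1.3-fold lower number from compound 2 to compound 3 (0.10 log units; within the scatter) that is expected to lie within the scatter of this assay. The estimate for compound 3 in this assay is 8000 nM, expected between 3000 nM and 20000 nM.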

Compound 3, half-maximal cytotoxic concentration: 10900 nM
Beside the measured number, compound 3's estimate is 1.4-fold (0.13 log units) below it, within the range that was stated.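

In this assay, the exchange on this aromatic carbon, para to a large group, gives a 1.1-fold higher number from compound 2 to compound 3 (0.04 log units; within the scatter). A phenoxy, with its 7 heavy atoms and its six-membered aromatic ring, can therefore stand in place of a fluoro of 1 heavy atom at this position without a shift in the read-out that clears the usual scatter. Among the compounds shown here, this is the first step in the set with a measured number at both ends, so it gives the first direct reading of a change at this position.

From the compounds shown here alone, whether an amine or a carboxylic acid on this same carbon would leave the number where it is stays open. Compound 1 differs from compound 2 in more than one place and is known only as a limit, so it gives no step to compare with this one: the limit of > 20000 nM in this assay, at which 1 of the 3 values shown sits.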